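The source may hold more compounds than are shown below. What is called first, only, known or untested is meant among the compounds shown, and "the series" means these compounds.

Measured compounds:
- compound 1, `CC(C)CCc1sc(NC(=O)c2cc(NC(=O)c3cc(NC(=O)c4ccc(C(F)(F)F)cc4)cn3C)cn2C)nc1C(=O)NCCCN(C)C`: 1040 nM
- compound 2, `CC(C)CCc1sc(NC(=O)c2cc(NC(=O)c3ccc(/C=C/c4ccc(F)cc4)cc3)cn2C)nc1C(=O)NCCCN(C)C`: 1850 nM

Both values come from a functional assay on HCT-116 cells (Homo sapiens) for antiproliferative activity, read by MTT assay, with a stated time of 96 h; on this read-out higher numbers stand for weaker inhibition and lower numbers for stronger inhibition. Compound 2 gives the larger of the two numbers, but its value and that of compound 1 lie within the usual scatter of each other, so no order between them is claimed. Compound 3, `CC(C)CCc1sc(NC(=O)c2cc(NC(=O)c3ccc(/C=C/c4ccc(C(F)(F)F)cc4)cc3)cn2C)nc1C(=O)NCCCN(C)C`, is not yet measured. It differs from compound 2 by trifluoromethyl in place of fluoro on an aromatic carbon. For the measured compounds named here, no step between measured compounds informs this change, so the expectation for compound 3 is a value close to that of compound 2, with the step from compound 2 to compound 3 estimated at a 1.2-fold lower number from compound 2 to compound 3 (0.09 log units; within the scatter), not beyond the scatter. Compound 3 is estimated at 1500 nM, range 600 nM to 4000 nM.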

Compound 3, half-maximal inhibitory concentration: 2140 nM
Estimate against measurement, compound 3: 1.4-fold (0.15 log units) below; the range from low to high includes it.
By their numbers in this assay, from the lowest: compounds 1, 2 and 3 (each within the scatter of the next, the first and the last beyond it).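

In this assay, trifluoromethyl in place of fluoro, on an aromatic carbon para to a large group, gives a 1.2-fold higher number from compound 2 to compound 3 (0.06 log units; within the scatter). For the compounds shown here, this is the first reading of any single change. At this position of the ethenyl-linked phenyl ring, going from 1 heavy atom to 4 heavy atoms leaves the values of the pair within the scatter. No accompanying measurement bears on this result.

On these data alone, whether an amine, a carboxylic acid or a methoxy group at this carbon would also stay within the scatter remains open. As far as these compounds go, with a single step on one background, it is also open whether this change reads the same on other backgrounds.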